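Bromo for methoxy on the pendant aryl ring

The compounds below may be only part of what the source reports. "The series", "measured", "known", "first", "only" and "open" are said of these compounds alone.

Measured compounds:
compound 1 `COc1ccc(-c2ccnc(Nc3cccc(OC)c3)n2)cc1` gives 550 nM
compound 3 `COc1ccc(-c2ccnc(Nc3ccc(Cl)cc3)n2)cc1` gives 310 nM
compound 2 `Clc1ccc(Nc2nccc(-c3ccc(Br)cc3)n2)cc1` gives 36700 nM

All three were tested in a functional assay on HeLa cells (Homo sapiens) for antiproliferative activity, read by MTT assay; a lower number here means a stronger inhibitor, a higher number a weaker inhibitor. Compound 1 and compound 3 carry the same methoxy group on the pendant aryl ring and differ in their anilino part; the difference between the two cores is not broken down here. Their values lie within the usual scatter of each other, so nothing can be said about an order between them. Within the data shown here, the one counted change in the set is bromo in place of methoxy on an aromatic carbon, and it made the step of a 120-fold higher number from compound 3 to compound 2 (2.07 log units; beyond the scatter).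

Compound 4 `COc1cccc(Nc2nccc(-c3ccc(Br)cc3)n2)c1` has not yet been measured. It relates to compound 1 as compound 2 relates to compound 3: the change is bromo in place of methoxy on an aromatic carbon, the same change at the same kind of place. Given the size of the step seen from compound 3 to compound 2, a step of similar size is expected here, a 91-fold higher number from compound 1 to compound 4 (1.96 log units; beyond the scatter), because of a 120-fold higher number from compound 3 to compound 2 (2.07 log units; beyond the scatter). Among the measured compounds shown here, with only one precedent, the width is kept broad. Compound 4 is therefore estimated at 50000 nM, within 12000 nM to 200000 nM.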

Compound 4, half-maximal inhibitory concentration: 153000 nM
Compound 4: middle estimate off by 3.1-fold (0.49 log units), on the low side, within the range that was stated.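

In this assay, bromo in place of methoxy on an aromatic carbon gave a 280-fold higher number from compound 1 to compound 4 (2.44 log units; beyond the scatter), so the large rise in the number seen on the core of compound 3 recurs on the core of compound 1. The two steps point the same way and do not differ in size beyond the scatter, so this change carried over between the two cores: the same change on two cores in this assay, a 120-fold higher number (2.07 log units; beyond the scatter) from compound 3 to compound 2 and a 280-fold higher number (2.44 log units; beyond the scatter) from compound 1 to compound 4, 2.3-fold (0.37 log units) apart, within the scatter of two such steps. Among these compounds, this covers only two cores, each with the change at the same kind of place, and it does not show that the step would hold on a core with a different anilino part, nor what produces it.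

Still open, from the compounds shown here alone, is whether the higher number follows from methoxy leaving or from bromo entering, a question on which a hydroxy group, an amine or a carboxylic acid at that carbon could bear. Also open, going by these compounds, is whether a longer alkoxy chain in place of methoxy would stay close to compound 1 at 550 nM.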